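Swapping Cyclopropylamino for Isopropylsulfanyl: Expected Cytotoxicity

A few compounds are considered here, and "the series" means these few. Any claim that something is new, unique, unknown or untested is made for them only; others in the source may bear on it.

The compounds here share one core and differ in a single group on an aromatic carbon. Compound 1 `C=CCOc1nc(N)nc2c1ncn2/C=C1/CC1(CO)CO` carries an allyloxy group, compound 2 `CN(C)c1nc(N)nc2c1ncn2/C=C1/CC1(CO)CO` a dimethylamino group, and compound 3 `Nc1nc(NC2CC2)c2ncn(/C=C3/CC3(CO)CO)c2n1` a cyclopropylamino group. All three were tested in an ADME assay on BCBL1 cells (Homo sapiens) for cytotoxicity, with a stated time of 7 days; on this read-out lower numbers stand for higher toxicity in this test and higher numbers for lower toxicity in this test. For compound 1 the result is a limit rather than a number, > 20000 nM. For compound 2 the result is likewise a limit, > 20000 nM. Within the data shown here, compound 3 is the only one with an actual number, giving 71500 nM in this assay. Among the measured compounds shown here, because two of the three results sit at the limit of > 20000 nM in this assay, at which 2 of the 3 values shown sit, none of the measured steps can be read: a step that the two limits leave unreadable from compound 1 to compound 2, a step that the limit leaves unreadable from compound 1 to compound 3 and a step that the limit leaves unreadable from compound 2 to compound 3. Compound 4 `CC(C)Sc1nc(N)nc2c1ncn2/C=C1/CC1(CO)CO` is not yet measured. It differs from compound 3 by isopropylsulfanyl in place of cyclopropylamino on an aromatic carbon. All three measured steps touch the same place, but none shows a size, so they give no direction for the change to compound 4, and no step beyond the scatter is expected. Compound 4 is thus expected to differ little in this respect, an expected step of a 1.4-fold lower number from compound 3 to compound 4 (0.16 log units; within the scatter). The estimate for compound 4 in this assay is 50000 nM, with a range from 15000 nM to 150000 nM.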

Compound 4, half-maximal cytotoxic concentration: > 20000 nM
Compound 4: a limit, no number; the forecaster's own chance of this, stated with the estimate: 50%; the middle value does not contradict the limit.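

Among these compounds, compound 4 gives only a limit, not a number, in this assay, so no step linking it to compound 1, compound 2 or compound 3 can be read: the limit of > 20000 nM in this assay, at which 3 of the 4 values shown sit. The compounds shown leave open how far the isopropylsulfanyl, allyloxy, dimethylamino and cyclopropylamino groups differ from one another in this assay.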